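A Second Trifluoromethyl Group on a Sulfone-Linked Ring

The compounds below may be only part of what the source reports. "The series", "measured", "known", "first", "only" and "open" are said of these compounds alone.

Of the compounds shown here, three have been tested in a functional assay on DU-145 cells (Homo sapiens) for antiproliferative activity, read by propidium iodide staining, with a stated time of 96 h; a higher number here means a weaker inhibitor, a lower number a stronger inhibitor. Compound 1, `CC(O)(COc1ccc(C#N)cc1)C(=O)Nc1cccc(S(F)(F)(F)(F)F)c1`, gives 42600 nM. Compound 2, `CC(O)(COc1ccc(C#N)cc1C(F)(F)F)C(=O)Nc1cccc(S(F)(F)(F)(F)F)c1`, gives 22800 nM. The two differ in one place: trifluoromethyl in place of hydrogen on an aromatic carbon. That change gave a 1.9-fold lower number from compound 1 to compound 2 (0.27 log units; within the scatter).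

Compound 3, `CC(O)(CS(=O)(=O)c1cccc(C(F)(F)F)c1)C(=O)Nc1ccc(S(F)(F)(F)(F)F)cc1`, gives 31900 nM in this assay. The difference between the core of compound 3 and the core of compound 1 is not broken down here; their two values lie close together.

Compound 4, `CC(O)(CS(=O)(=O)c1cc(C(F)(F)F)cc(C(F)(F)F)c1)C(=O)Nc1ccc(S(F)(F)(F)(F)F)cc1`, has not been measured. It differs from compound 3 by trifluoromethyl in place of hydrogen on an aromatic carbon. This is the same kind of change as that from compound 1 to compound 2, but the surroundings differ: in compound 2 the new group sits ortho to a large group and meta to a cyano group, while in compound 4 it sits meta to a large group and meta to a trifluoromethyl group.

Because the earlier change gave only a 1.9-fold lower number from compound 1 to compound 2 (0.27 log units; within the scatter), a step of similar modest size is expected, a 1.5-fold lower number from compound 3 to compound 4 (0.18 log units; within the scatter). Compound 4 is therefore estimated at 21000 nM, with a likely range from 9000 nM to 50000 nM.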

Compound 4, half-maximal inhibitory concentration: 24400 nM
Estimate against measurement, compound 4: 1.2-fold (0.07 log units) below, and the stated range covers the measured number.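

Trifluoromethyl in place of hydrogen on an aromatic carbon gave a 1.3-fold lower number from compound 3 to compound 4 (0.12 log units; within the scatter) in this assay. Set beside the earlier step, the same change on the other core cannot be told apart from this one, so as far as this assay can show it carries across the two cores without a detectable difference: the same change on two cores in this assay, a 1.9-fold lower number (0.27 log units; within the scatter) from compound 1 to compound 2 and a 1.3-fold lower number (0.12 log units; within the scatter) from compound 3 to compound 4, 1.4-fold (0.16 log units) apart, within the scatter of two such steps. This agreement is weak support, since each step is itself within the scatter, so the data do not show that the change truly lowers the number on either core, and two cores cannot establish a rule for the series.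

The compounds shown leave open whether a different group on that aromatic carbon, such as a chlorine atom, a methoxy group or an amine, would give a step beyond the scatter. From the compounds shown here alone, whether a carboxylic acid in place of the nitrile of compound 2 would do so also remains open.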